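Working notes: cytotoxicity of compounds 1 to 3

This account rests on a few compounds, and the source may have more. Where it says the series, first, only, none or still open, it means among the compounds named here.

Measured so far:
compound 1 `Cc1c(Cc2ccccc2)c(=O)oc2cc(OCC(O)CNCC3CC3)ccc12`: in an ADME assay on A549 cells (Homo sapiens) for cytotoxicity, read by CellTiter-Glo (on this read-out lower numbers stand for higher toxicity in this test and higher numbers for lower toxicity in this test), compound 1 reports only the assay limit, > 100000 nM.
compound 2 `Cc1c(Cc2ccc(Br)cc2)c(=O)oc2cc(OCC(O)CN3CCC(C(N)=O)CC3)ccc12`: in this assay compound 2 likewise reports only the assay limit, > 100000 nM.

For the measured compounds named here, compound 2 therefore stands at the limit of this assay rather than at a number, and the one further value shown is a limit as well, so both values shown sit together at the limit of > 100000 nM in this assay, at which 2 of the 2 values shown sit. Going by the values given here, no step between measured compounds can be read from this, and nothing separates compound 1 from compound 2 on these numbers.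

Compound 3 `Cc1c(Cc2ccc(C(F)(F)F)cc2)c(=O)oc2cc(OCC(O)CN3CCC(C(N)=O)CC3)ccc12` differs from compound 2 by trifluoromethyl in place of bromo on an aromatic carbon. With both measured values resting at the limit (the limit of > 100000 nM in this assay, at which 2 of the 2 values shown sit), no step beyond the usual scatter is expected in this assay, in either direction. The step from compound 2 to compound 3 is expected to be a number no higher from compound 2 to compound 3 (the limit leaves the size open). Compound 3 is estimated at 100000 nM, within 40000 nM to 250000 nM, and is expected most likely to be reported again only as a limit.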

Compound 3, half-maximal cytotoxic concentration: 89300 nM
The estimate for compound 3 lay 1.1-fold (0.05 log units) above the measured number; the range from low to high includes it.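

For the compounds shown here, at this place, on an aromatic carbon para to a large group, trifluoromethyl in place of bromo gives the first actual number of the series in this assay: compound 3 gives 89300 nM. The change reads as an at least 1.1-fold lower number from compound 2 to compound 3 (0.04 log units; that floor lies within the scatter), and only that floor can be stated, as the starting value is a limit and the true size of the step remains unread. The series can therefore register a number in this test, although most of the values shown still rest at the ceiling: the limit of > 100000 nM in this assay, at which 2 of the 3 values shown sit.

As far as these compounds go, whether other groups at this place, such as chloro, nitrile or methoxy, would give a number in this assay or stay at the limit remains open, and so does the size of any difference between them and trifluoromethyl. Also open, from the compounds shown here alone, is how the number of compound 3 would respond to a change in the side chain, such as a carboxylic acid in place of the primary amide, with the 4-(trifluoromethyl)benzyl group kept.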